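Compound 1 to compound 4: phenoxy to hydroxy

The source may hold more compounds than are shown below. What is called first, only, known or untested is meant among the compounds shown, and "the series" means these compounds.

Values in a functional assay on A549 cells (Homo sapiens) for cytotoxicity, read by MTT assay, with a stated time of 48 h (on this read-out lower numbers stand for stronger inhibition and higher numbers for weaker inhibition), each of them a limit:
Compound 1 `O=S(=O)(c1ccc(-n2cc(COc3ccccc3)nn2)cc1)N1CCc2ccccc2C1`: > 50 ug/mL
Compound 2 `COc1cc2c(cc1OC)CN(S(=O)(=O)c1ccc(-n3cc(COc4ccc(C)cc4)nn3)cc1)CC2`: > 50 ug/mL
Compound 3 `COc1cc2c(cc1OC)CN(S(=O)(=O)c1ccc(-n3cc(COc4ccccc4)nn3)cc1)CC2`: > 50 ug/mL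

Compound 1 stands only at a limit, > 50 ug/mL. The other measured compounds sit there too: the limit of > 50 ug/mL in this assay, at which 3 of the 3 values shown sit. The next compound is compound 4 `O=S(=O)(c1ccc(-n2cc(CO)nn2)cc1)N1CCc2ccccc2C1`, with the change (hydrogen in place of phenyl on an oxygen on a saturated carbon); cut one bond further out, this reads phenoxy to hydroxy. Going by the values given here, the only measured step, a step that the two limits leave unreadable from compound 2 to compound 3, concerns a different change and gives no size to carry over. Since compound 1 holds only the limit > 50 ug/mL, compound 4 is expected to show no step beyond the scatter in this assay, and no direction can be assigned. The estimated step is a step that the limit leaves unreadable from compound 1 to compound 4. Compound 4 is estimated at 70 ug/mL, with an expected range of 40 ug/mL to 150 ug/mL.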

Compound 4, half-maximal inhibitory concentration: > 50 ug/mL
Compound 4 ended at the assay's limit; the forecaster's own chance of this, stated with the estimate: 85%; the middle value does not contradict the limit.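

No step can be read from compound 1 to compound 4, because both values are limits: the limit of > 50 ug/mL in this assay, at which 4 of the 4 values shown sit. The compounds shown leave open what the change from phenoxy to hydroxy does to potency, and how these four compounds rank.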